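A few compounds are considered here, and "the series" means these few. Any claim that something is new, unique, unknown or untested is made for them only; others in the source may bear on it.

Measured so far in a functional assay on NCI-H460 cells (Homo sapiens) for cytotoxicity, read by MTT assay, with a stated time of 72 h; on this read-out lower numbers stand for stronger inhibition and higher numbers for weaker inhibition:
compound 1 `CN(C)CCCNc1nc(-c2ccc(NC(=O)Nc3ccc(F)cc3)cc2)nc2c(Cl)c(Cl)sc12` gives 650 nM
compound 2 `CN(C)CCNc1nc(-c2ccc(NC(=O)Nc3ccccc3)cc2)nc2ccsc12` gives 640 nM

Compound 2 stands level with compound 1: the two numbers lie within the scatter of each other, so no order between them can be read. Compound 3 `CN(C)CCNc1nc(-c2ccc(NC(=O)Nc3ccccc3F)cc2)nc2ccsc12` is not yet measured. It differs from compound 2 by fluoro in place of hydrogen on an aromatic carbon, ortho to a large group. Within the data shown here, no measured pair informs this change, and the two numbers in hand point neither way. The step is expected to be a 1.1-fold lower number from compound 2 to compound 3 (0.03 log units; within the scatter), none beyond the scatter. Compound 3 is estimated at 600 nM, range 250 nM to 1500 nM.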

Compound 3, half-maximal inhibitory concentration: 410 nM
The estimate for compound 3 lay 1.5-fold (0.17 log units) above the measured number; the measured number falls inside the stated range.
By their numbers in this assay, from the lowest: compounds 3, 2 and 1 (each within the scatter of the next).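

In this assay, among these compounds, the first reading at this position, fluoro in place of hydrogen on an aromatic carbon ortho to a large group, gives a 1.6-fold lower number from compound 2 to compound 3 (0.19 log units; within the scatter) and so sets no order between the two compounds. On this one pair, phenyl to 2-fluorophenyl shows no change that can be told from the scatter, and it cannot speak for other substituents. No evidence bearing on this step is at hand.

From the compounds shown here alone, whether chloro, methyl or methoxy in the same place would move the number beyond the scatter stays open. So does whether fluoro elsewhere on this ring would read the same way.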